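This account rests on a few compounds, and the source may have more. Where it says the series, first, only, none or still open, it means among the compounds named here.

In a functional assay on LNCaP cells (Homo sapiens) for inhibition, read by WST assay, with a stated time of 3 days (a higher number here means a weaker inhibitor, a lower number a stronger inhibitor), compound 1 `Cn1ccnc1/C=C/C(=O)/C=C/c1coc2ccccc2c1=O` gives 2300 nM and compound 2 `CC(C)n1ccnc1/C=C/C(=O)/C=C/c1coc2ccccc2c1=O` gives 1200 nM, so compound 2 stands level with compound 1 within the scatter. Compound 3 `CCCC(C)n1ccnc1/C=C/C(=O)/C=C/c1coc2ccccc2c1=O` has ethyl in place of hydrogen on a saturated chain carbon, two bonds along the chain from an aromatic nitrogen. For the measured compounds named here, the only measured step that bears on this, a 1.9-fold lower number from compound 1 to compound 2 (0.28 log units; within the scatter), is isopropyl in place of methyl on an aromatic nitrogen. Going by the values given here, with that step as the sole guide, no change beyond the scatter is expected in this assay. The expected step is a 1.2-fold lower number from compound 2 to compound 3 (0.08 log units; within the scatter). Compound 3 is estimated at 1000 nM, with an expected range of 400 nM to 2500 nM.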

Compound 3, half-maximal inhibitory concentration: 3900 nM
Beside the measured number, compound 3's estimate is 3.9-fold (0.59 log units) below it, outside the stated range (above it).
By their numbers in this assay, from the lowest: compounds 2, 1 and 3 (each within the scatter of the next, the first and the last beyond it).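

In this assay, for the compounds shown here, ethyl in place of hydrogen on this saturated chain carbon gives the first step beyond the scatter (a 3.3-fold higher number from compound 2 to compound 3 (0.51 log units; beyond the scatter)), so the position does not accept every extension of the isopropyl group. Against the methyl group of compound 1, the 1-methylbutyl group of compound 3 stands level within the scatter (a 1.7-fold higher number from compound 1 to compound 3 (0.23 log units; within the scatter)). No evidence on hand bears on this step.

Still open, as far as these compounds go, is whether a hydroxyl or an amine at this chain carbon would hold the number of compound 2. Also open, from the compounds shown here alone, is how a longer chain or a phenyl group on the aromatic nitrogen would compare.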